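Chloro Steps in an Anti-Edema Pyrimidine Series

The source may report more compounds than this note shows. Statements on the series, on what has been measured and on what is new or still open speak of the compounds shown alone.

Measured compounds:
- compound 1, `N#Cc1c(Nc2ccccc2)nc(SCC(=O)Nn2c(COc3ccc(Cl)cc3Cl)nc3ccccc3c2=O)nc1-c1ccccc1`: 78.1%
- compound 2, `N#Cc1c(Nc2ccccc2)nc(SCC(=O)Nn2c(COc3ccc(Cl)cc3Cl)nc3ccccc3c2=O)nc1-c1ccc(Cl)cc1`: 50.9%
- compound 3, `N#Cc1c(Nc2ccccc2)nc(SCC(=O)Nn2c(COc3ccc(Cl)cc3Cl)nc3ccccc3c2=O)nc1-c1ccc(O)cc1`: 91.2%

In a functional assay on the whole organism (strain albino) for inhibition, with Rattus norvegicus as the target, read by paw edema, with stated times of 1 h and 2 h, at a dose of 100 mg/kg by the oral route (on this read-out lower numbers stand for less inhibition and higher numbers for more inhibition at the one dose given (going by the name of the read-out)), compound 1 gives 78.1%, compound 2 gives 50.9% and compound 3 gives 91.2%. The step of a number 27.2 percentage points lower from compound 1 to compound 2 (beyond the scatter) follows the change (chloro in place of hydrogen on an aromatic carbon). The step of a number 13.1 percentage points higher from compound 1 to compound 3 (beyond the scatter) follows the change (hydroxy in place of hydrogen on an aromatic carbon), and the step of a number 40.3 percentage points higher from compound 2 to compound 3 (beyond the scatter) makes compound 3 the highest of the three, with both of its steps beyond the scatter.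

Compound 4, `N#Cc1c(Nc2ccc(Cl)cc2)nc(SCC(=O)Nn2c(COc3ccc(Cl)cc3Cl)nc3ccccc3c2=O)nc1-c1ccc(O)cc1`, is not yet measured in this assay. It differs from compound 3 by chloro in place of hydrogen on an aromatic carbon. Compound 3 and compound 1 themselves differ by hydroxy in place of hydrogen on an aromatic carbon. The change from compound 3 to compound 4 is the same kind of change as from compound 1 to compound 2, with the same place; the difference cut one bond further out reads phenyl to 4-chlorophenyl in the first pair and anilino to (4-chlorophenyl)amino in the second, so the change sits on a different ring in compound 4.

Within the data shown here, the expectation for compound 4 rests on the single step of a number 27.2 percentage points lower from compound 1 to compound 2 (beyond the scatter), taken on a different ring, so a drop of similar direction but uncertain size is expected, and the step of a number 21.2 percentage points lower from compound 3 to compound 4 (beyond the scatter) is the estimate. Compound 4 is expected to give about 70% in this assay, between 50% and 88%.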

Compound 4, a percentage reported as inhibition, in the whole organism at one dose (the size of the read-out at that dose, not a potency): 77.2%
Compound 4: the middle estimate sits 7.2 percentage points below what was measured; the range from low to high includes it.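

In this assay, chloro in place of hydrogen on an aromatic carbon again goes with a lower number, a number 14 percentage points lower from compound 3 to compound 4 (beyond the scatter), so the direction of the earlier step holds on the core of compound 3 and the two sizes cannot be told apart: the same change on two cores in this assay, a number 27.2 percentage points lower (beyond the scatter) from compound 1 to compound 2 and a number 14 percentage points lower (beyond the scatter) from compound 3 to compound 4, 13.2 percentage points apart, within the scatter of two such steps

The two steps are not a strict repeat, since the change reads phenyl to 4-chlorophenyl in the first pair and anilino to (4-chlorophenyl)amino in the second, so the agreement spans two different rings as well as two cores. Among these compounds, with only two pairs, this supports a shared direction for these compounds and gives no rule for other rings or cores; it also does not show whether the size of the step depends on the hydroxy group that compound 3 carries.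

The compounds shown leave open how a methoxy group, an amine or a carboxylic acid would read in place of the chloro on either ring, and whether chloro on both rings of one compound would lower the number further. Each figure also comes from a single dose, so the order of these compounds at other doses remains open.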